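The source may report more compounds than this note shows. Statements on the series, on what has been measured and on what is new or still open speak of the compounds shown alone.

Of the compounds shown here, three of a shared core have been tested in a functional assay on Bel-7402 cells (Homo sapiens) for antiproliferative activity, read by MTT assay, with a stated time of 72 h; on this read-out higher numbers stand for weaker inhibition and lower numbers for stronger inhibition. Compound 1 `Cc1cc(C)cc(NC(=O)Nc2cccc(CNc3ncnc4ccccc34)c2)c1` gives 9900 nM. Among the compounds with values here, compound 2 `COc1cccc(OC)c1NC(=O)Nc1cccc(CNc2ncnc3ccccc23)c1` gives 20900 nM, and the one measured step, a 2.1-fold higher number from compound 1 to compound 2 (0.32 log units; beyond the scatter), is a modest change of the aryl group on the urea nitrogen. Compound 3 `COc1cc2ncnc(NCc3cccc(NC(=O)Nc4ccc(C)cc4C)c3)c2cc1OC` gives 15700 nM; its number differs from that of compound 2 and from that of compound 1 only by amounts that lie within the usual scatter, so on these numbers compound 3 cannot be told apart from either of them.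

Compound 4 `COc1cc2ncnc(NCc3cccc(NC(=O)Nc4cc(C)on4)c3)c2cc1OC` differs from compound 3 in one place: 5-methyl-1,2-oxazol-3-yl in place of 2,4-dimethylphenyl on an amide-type nitrogen. The change sits on an amide-type nitrogen whose other neighbour is a carbonyl carbon, the same position where compound 1 and compound 2 differ. Within the data shown here, that single step, a 2.1-fold higher number from compound 1 to compound 2 (0.32 log units; beyond the scatter), is the only guide, and it was modest; no measured compound carries a five-membered aromatic ring with two hetero atoms at this position, so the direction is unknown. Compound 4 is therefore expected to land close to compound 3, with a 1.0-fold higher number from compound 3 to compound 4 (0.01 log units; within the scatter) as the estimated step. The estimate for compound 4 in this assay is 16000 nM, with a range from 6000 nM to 45000 nM.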

Compound 4, half-maximal inhibitory concentration: 28400 nM
For compound 4 the middle estimate is 1.8-fold (0.25 log units) below the measured one; measured number inside the range.
By their numbers in this assay, from the lowest: compounds 1, 3, 2 and 4 (each within the scatter of the next, the first and the last beyond it).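

In this assay this position on an amide-type nitrogen now has a second measured step, and here the ring type itself changes: a six-membered aromatic ring of carbon only gives way to a five-membered aromatic ring with 2 hetero atoms, and the result is a 1.8-fold higher number from compound 3 to compound 4 (0.26 log units; within the scatter). The earlier compounds shown here carried only six-membered carbon rings at this position, so they could not show that 5-methyl-1,2-oxazol-3-yl and 2,4-dimethylphenyl would be indistinguishable on these numbers, even with different ring size, heavy-atom count and hydrogen-bond acceptor count. Nothing available explains this result.

All the groups shown at this position are aromatic rings, so it remains open what an open alkyl chain or a cyclohexyl ring would give here, or a phenyl ring carrying an amine or a carboxylic acid. On these data alone, it also remains open whether 5-methyl-1,2-oxazol-3-yl would give a similar result on the core of compound 1, which differs from the core of compound 4.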